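Swapping methyl for tert-butoxycarbonyl on compound 1

A few compounds are considered here, and "the series" means these few. Any claim that something is new, unique, unknown or untested is made for them only; others in the source may bear on it.

- Compound 1 `CN1CCN(CC#Cc2cc3ncnc(Nc4ccc(OCc5cccc(F)c5)c(Cl)c4)c3s2)CC1` gives 4.8 uM
- Compound 2 `Fc1cccc(COc2ccc(Nc3ncnc4cc(C#CCN5CCCC5)sc34)cc2Cl)c1` gives 6.4 uM
- Compound 3 `Fc1cccc(COc2ccc(Nc3ncnc4cc(C#CC5CCCC5)sc34)cc2Cl)c1` gives > 100 uM (a limit of the assay, not a number)

All three values come from an ADME assay on NIH3T3 cells (Mus musculus) for cytotoxicity (on this read-out higher numbers stand for lower toxicity in this test and lower numbers for higher toxicity in this test), and share one core. Compound 1 gives 4.8 uM here and stands level with compound 2 within the scatter. Compound 3 reports only the limit > 100 uM and so gives no exact number.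

Compound 4 `CC(C)(C)OC(=O)N1CCN(CC#Cc2cc3ncnc(Nc4ccc(OCc5cccc(F)c5)c(Cl)c4)c3s2)CC1` awaits measurement. It carries tert-butoxycarbonyl in place of methyl on an amine nitrogen in a ring of compound 1. Going by the values given here, no measured compound carries this group, so the evidence is indirect. Exchanging one amine ring for another gave a 1.3-fold higher number from compound 1 to compound 2 (0.12 log units; within the scatter) and left the number within the scatter. Replacing the amine ring and its chain carbon with cyclopentyl gave much larger steps, an at least 20-fold higher number from compound 1 to compound 3 (1.31 log units; beyond the scatter) and an at least 15-fold higher number from compound 2 to compound 3 (1.19 log units; beyond the scatter) in turn. Compound 4 keeps that ring and chain carbon, so only part of an at least 20-fold higher number from compound 1 to compound 3 (1.31 log units; beyond the scatter) is expected, and the outcome remains uncertain. The expected change is a modest rise, a 3.1-fold higher number from compound 1 to compound 4 (0.49 log units; beyond the scatter) as estimated. For compound 4 the estimated value is 15 uM with an expected range from 5 uM to 60 uM in this assay.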

Compound 4, half-maximal toxic concentration: 47 uM
Compound 4: middle estimate off by 3.1-fold (0.50 log units), on the low side; low and high end bracket the measured number.
By their numbers in this assay, from the lowest: compounds 1 and 2 (each within the scatter of the next); then compound 4. At a limit, above all of these: compound 3.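

The new step shows that the substituent on the amine nitrogen in the ring matters in this assay, even when the ring and the chain carbon holding it stay in place: a 9.8-fold higher number from compound 1 to compound 4 (0.99 log units; beyond the scatter). The earlier compounds shown here could not show this, as they either exchanged one whole amine ring for another, which left the number within the scatter, or removed the amine ring and its chain carbon together. Here the only change is at the ring nitrogen, where a single-carbon methyl gives way to the seven heavy atoms of tert-butoxycarbonyl, and compound 4 gives an exact number rather than reaching the upper limit of the test: the limit of > 100 uM in this assay, at which 1 of the 4 values shown sits.

Going by these compounds, what remains open is which part of tert-butoxycarbonyl goes with the higher number, the carbonyl or the tert-butyl part, as the change brings both at once. An acetyl group or a plain tert-butyl group on the same nitrogen would help separate the two, while a hydrogen there would show how the number responds when the methyl is simply taken away.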